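Adding a Benzyloxy Group to a Small Acetanilide

The source may hold more compounds than are shown below. What is called first, only, known or untested is meant among the compounds shown, and "the series" means these compounds.

Of the compounds shown here, three have so far been tested in an assay on HEK293 cells for displacement of a labelled ligand from Translocator protein (Homo sapiens), read by scintillation counting, with a stated time of 90 min; a lower number here means a stronger inhibitor, a higher number a weaker inhibitor. Compound 1, `CCN(CC)C(=O)c1nc2ccccc2n1Cc1ccccc1`, gives > 10000 nM, which is a limit of the assay rather than a number, as recorded in the limit of > 10000 nM in this assay, at which 1 of the 3 values shown sits. Compound 2, `C#CCN(C)C(=O)c1cc2cc(NC(C)=O)ccc2n1Cc1ccc(OC)cc1`, gives 2860 nM. Compound 3, `CC(=O)N(Cc1ccccc1)c1cc(C)cc(C)c1`, gives 1260 nM, the lowest of the two numbers shown; the number for compound 2 sits higher by a margin beyond the usual scatter, so compound 3 is the stronger binder of the two that have numbers.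

Compound 4, `CC(=O)N(Cc1ccc(OCc2ccccc2)cc1)c1cc(C)cc(C)c1`, differs from compound 3 in one place only: benzyloxy in place of hydrogen on an aromatic carbon. Among the measured compounds shown here, no step between two measured compounds shows what such an addition does here, so any expectation rests on the change itself and on how compound 3 already stands. A group of this size, attached at the far end of the benzyl arm, is expected to shift the number by a modest amount toward stronger binding, with the step from compound 3 to compound 4 estimated as a 3.2-fold lower number from compound 3 to compound 4 (0.50 log units; beyond the scatter). On that basis compound 4 is expected to give about 400 nM, with a likely range from 100 nM to 1500 nM.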

Compound 4, inhibition constant: 738 nM
Beside the measured number, compound 4's estimate is 1.8-fold (0.27 log units) below it; the measured number falls inside the stated range.
By their numbers in this assay, from the lowest: compounds 4 and 3 (each within the scatter of the next); then compound 2. At a limit, above all of these: compound 1.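

In this assay, among the compounds shown here, the exchange of hydrogen for benzyloxy on an aromatic carbon, para to a large group, gives a 1.7-fold lower number from compound 3 to compound 4 (0.23 log units; within the scatter) and this is the first measured step at this position. A step of that size cannot be told apart from repeat-to-repeat variation, so the change neither clearly strengthens nor clearly weakens binding. What it does show is that this position can carry a group of 8 heavy atoms, including a six-membered aromatic ring, with no loss of binding that can be detected, although nothing measured here accounts for that outcome.

A single step cannot show whether this position ever matters for binding, and an amine, a carboxylic acid or a hydroxyl group in the same place might or might not move the number beyond the scatter. On these data alone, it also remains open whether a longer chain ending in the same aromatic ring, or benzyloxy on another of the aromatic carbons, would give a clearer change.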